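The source may hold more compounds than are shown below. What is called first, only, known or untested is meant among the compounds shown, and "the series" means these compounds.

Compound 3 `O=c1cc(Cn2cc(CCCCO)nn2)c2ccc(O)cc2o1` was examined in a functional assay on HepG2 cells (Homo sapiens) for inhibition, read by MTT assay, with a stated time of 72 h; a lower number here means a stronger inhibitor, a higher number a weaker inhibitor. In this assay compound 3 gives only > 100000 nM, which is a limit of the assay and not a number. Compound 1 `O=c1cc(Cn2cc(CCCCl)nn2)c2ccc(O)cc2o1` likewise gives only the limit > 100000 nM. Compound 2 `O=c1cc(Cn2cc(CCO)nn2)c2ccc(O)cc2o1` gives the limit > 100000 nM. For that reason the steps a step that the two limits leave unreadable from compound 1 to compound 2, a step that the two limits leave unreadable from compound 1 to compound 3 and a step that the two limits leave unreadable from compound 2 to compound 3 stay unreadable, since all three values rest at the limit of > 100000 nM in this assay, at which 3 of the 3 values shown sit. Compound 4 `O=c1cc(Cn2cc(-c3cc(F)cc(F)c3)nn2)c2ccc(O)cc2o1` differs from compound 3 by 3,5-difluorophenyl in place of 4-hydroxybutyl on an aromatic carbon. Going by the values given here, none of the measured steps covers such a change, so no step of readable size can be foreseen for compound 4 in this assay. Compound 4 is estimated at 60000 nM, within a range from 10000 nM to 300000 nM. The expected step is an at least 1.6-fold lower number from compound 3 to compound 4 (0.22 log units; that floor lies within the scatter), and this assay may again report only a limit.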

Compound 4, half-maximal inhibitory concentration: 38900 nM
Compound 4: middle estimate off by 1.5-fold (0.19 log units), on the high side; the measured number falls inside the stated range.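

In this assay the 3,5-difluorophenyl group on this aromatic carbon gives an at least 2.5-fold lower number from compound 3 to compound 4 (0.41 log units; beyond the scatter) and an at least 2.5-fold lower number from compound 2 to compound 4 (0.41 log units; beyond the scatter) and an at least 2.5-fold lower number from compound 1 to compound 4 (0.41 log units; beyond the scatter) and so moves off the limit that the chain compounds share. It is the only change shown here that gives a step of readable size, though only as a floor. Compound 1, compound 2 and compound 3 each give only a limit, so the true size of these steps cannot be read: the limit of > 100000 nM in this assay, at which 3 of the 4 values shown sit.

Going by these compounds, whether the step comes from the phenyl ring or from its two fluorine atoms stays open. So does what an unsubstituted phenyl, an amine or a carboxylic acid would give at this position.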